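A few compounds are considered here, and "the series" means these few. Any claim that something is new, unique, unknown or untested is made for them only; others in the source may bear on it.

Measured compounds in this set:

Compound 1, `O=C(NCCCCc1ccccc1)c1cccc(C2SCC(=O)N2c2ccccc2)c1`: in a functional assay on MG-63 cells (Homo sapiens) for inhibition, read by CCK-8 assay, with a stated time of 72 h, tested at 1 uM (a higher number here means more inhibition at the concentration tested (going by the name of the read-out), a lower number less inhibition), compound 1 gives 89%.
Compound 2, `Cc1cccc(N2C(=O)CSC2c2cccc(C(=O)NCCCCc3ccccc3)c2)c1`: in this assay compound 2 gives 93%.
Compound 3, `O=C(NCCCCc1ccccc1)c1cccc(C2SCC(=O)N2c2cccc(F)c2)c1`: in this assay compound 3 gives 92%.

Compound 3 sits second highest of the three numbers, but its neighbours are close: the step of a number 1 percentage points lower from compound 2 to compound 3 (within the scatter) and the step of a number 3 percentage points higher from compound 1 to compound 3 (within the scatter) both lie within the scatter, as does the step of a number 4 percentage points higher from compound 1 to compound 2 (within the scatter). In short, the three measured compounds cannot be told apart on these numbers.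

Compound 4, `CC(F)(F)c1cccc(N2C(=O)CSC2c2cccc(C(=O)NCCCCc3ccccc3)c2)c1`, differs from compound 3 in one place: 1,1-difluoroethyl in place of fluoro on an aromatic carbon. The measured steps that bear on this position are all small substituent swaps on the same aromatic carbon, and none moved the read-out beyond the scatter. Among the compounds with values here, nothing among the measured compounds speaks to a group as large as 1,1-difluoroethyl at this position, so the expectation rests on the flatness of the three values alone. Compound 4 is therefore expected to show no step beyond the scatter, with a number 4 percentage points lower from compound 3 to compound 4 (within the scatter) as the estimated change from compound 3. The estimate for compound 4 in this assay is 88%, within a range from 72% to 96%.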

Compound 4, a percentage reported as inhibition, at one concentration (the size of the read-out at that concentration, not a potency): 92%
Compound 4: middle estimate off by 4 percentage points, on the low side, and the stated range covers the measured number.
By their numbers in this assay, from the lowest: compounds 1, 3, 4 and 2 (each within the scatter of the next).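

In this assay, the aromatic carbon now carries 1,1-difluoroethyl, with 4 heavy atoms where fluoro has 1, and the read-out stays flat against each smaller group: fluoro (no change at the digits printed from compound 3 to compound 4 (within the scatter)), methyl (a number 1 percentage points lower from compound 2 to compound 4 (within the scatter)) and hydrogen (a number 3 percentage points higher from compound 1 to compound 4 (within the scatter)). The earlier compounds shown here showed this flatness only for hydrogen, methyl and fluoro, whereas compound 4 extends it to a branched, larger group at the same place. Nothing given here accounts for this lack of change.

From the compounds shown here alone, whether an amine, a carboxylic acid or a longer chain on this aromatic carbon would leave the number equally unmoved remains open. Also open is whether these four compounds, which cannot be told apart at the single concentration shown, would separate in a full concentration series.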